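From compound 1 to compound 4: a step among limits

The compounds below may be only part of what the source reports. "The series", "measured", "known", "first", "only" and "open" are said of these compounds alone.

Compound 1 (`O=C(Nc1cccc(-n2cc(-c3ccncc3)c(-c3ccc(Cl)c(O)c3)n2)c1)Nc1cccc(C(F)(F)F)c1`) is the starting point in a functional assay on SW-620 cells (Homo sapiens) for inhibition, read by sulforhodamine B assay, with a stated time of 48 h; on this read-out lower numbers stand for stronger inhibition of growth and higher numbers for weaker inhibition of growth. Compound 1 gives > 32500 nM as a limit of the assay. Compound 2 (`COc1cc(-c2nn(-c3cccc(NC(=O)c4cccc(C(F)(F)F)c4)c3)cc2-c2ccncc2)ccc1Cl`) gives > 50000 nM as a limit of the assay. Compound 3 (`O=C(Nc1cccc(-n2cc(-c3ccncc3)c(-c3ccc(Cl)c(O)c3)n2)c1)Nc1ccc(Cl)c(Cl)c1`) gives > 32500 nM as a limit of the assay. All three values shown are limits, so compound 1 has no measured rank among them.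

Compound 4 (`O=C(Nc1cccc(-n2cc(-c3ccncc3)c(-c3ccc(Cl)c(O)c3)n2)c1)Nc1cc(C(F)(F)F)cc(C(F)(F)F)c1`) differs from compound 1 by one change (trifluoromethyl in place of hydrogen on an aromatic carbon), with trifluoromethyl in place of hydrogen on an aromatic carbon, meta to a trifluoromethyl group. For the measured compounds named here, the one measured step that bears on this is a step that the two limits leave unreadable from compound 1 to compound 3, which also replaces the 3-(trifluoromethyl)phenyl group on an amide-type nitrogen. Going by the values given here, its size cannot be read, so no step of known size carries over to compound 4.

Since compound 3 holds at > 32500 nM as a limit, no step beyond the scatter is expected in this assay, and a limit is the likeliest report for compound 4. The expected step is a number no higher from compound 1 to compound 4 (the limit leaves the size open), and it remains an estimate. For compound 4 the estimated value is 32500 nM, with an expected range from 12000 nM to 60000 nM.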

Compound 4, concentration for total growth inhibition: 5110 nM
The estimate for compound 4 lay 6.4-fold (0.80 log units) above the measured number; the whole stated range lies above it.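

In this assay, an at least 6.3-fold lower number from compound 1 to compound 4 (0.80 log units; beyond the scatter) is the only step in the series shown whose size can be read, and it lies beyond the scatter; the steps among the limits cannot be read. It shows that this carbon of the six-membered aromatic ring is not silent: trifluoromethyl in place of hydrogen, meta to the trifluoromethyl group already present, takes the read-out from a limit to a measured number, which the 3,4-dichlorophenyl change did not do. The other three values remain limits of the assay, so compound 4 is the only compound here with a measured number: the limit of > 32500 nM in this assay, at which 2 of the 4 values shown sit.

From the compounds shown here alone, whether the lower number belongs to trifluoromethyl itself or would follow from other groups on the same carbon stays open, and a chlorine, a methyl, a nitrile or an amine there would begin to separate these cases. Also open, going by these compounds, is whether the same change would lower the number with a methoxy group in place of the hydroxyl group on the chlorophenyl ring, or in a read-out on any other cell line.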